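The source may hold more compounds than are shown below. What is called first, only, known or untested is meant among the compounds shown, and "the series" means these compounds.

Compound 1 `Cc1ccccc1NNC(=O)CCC(C)C`: 339 nM
Compound 2 `Cc1ccccc1NNC(=O)CC1CCCCC1`: 151 nM
Compound 3 `O=C(NNc1cccc2ncccc12)C1(c2ccccc2F)CCCCC1`: 324 nM

All three were measured in an in vitro functional assay on 1321-N1 cells for antagonist activity at P2X purinoceptor 7 (Rattus norvegicus), read by FLIPR and calcium flux; a higher number here means a weaker inhibitor, a lower number a stronger inhibitor. Compound 3 gives the second highest of the three numbers: its value and that of compound 1 lie within the scatter of each other, while compound 2 lies lower, beyond the scatter. Compound 4 `O=C(NNc1cccc2ncccc12)C1(c2ccc(F)cc2)CCCCC1` differs from compound 3 in one place: 4-fluorophenyl in place of 2-fluorophenyl on a saturated ring carbon. For the measured compounds named here, the single measured step, a 2.2-fold lower number from compound 1 to compound 2 (0.35 log units; beyond the scatter), concerns a different part of the molecule and does not bear on this change, so the data give no guide to it. Compound 4 is therefore expected to give about the same number as compound 3, no change at the digits printed from compound 3 to compound 4 (within the scatter), with no step beyond the scatter. The estimate for compound 4 in this assay is 324 nM, between 140 nM and 750 nM.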

Compound 4, half-maximal inhibitory concentration: 174 nM
For compound 4 the middle estimate is 1.9-fold (0.27 log units) above the measured one, and the stated range covers the measured number.
By their numbers in this assay, from the lowest: compounds 2, 4, 3 and 1 (each within the scatter of the next, the first and the last beyond it).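

In this assay, for the compounds shown here, the change to 4-fluorophenyl in place of 2-fluorophenyl on a saturated ring carbon gives a 1.9-fold lower number from compound 3 to compound 4 (0.27 log units; within the scatter), the first reading at this position, where the earlier compounds offered only a change on a saturated chain. At this position, the two fluorophenyl groups therefore cannot be told apart in this read-out. Nothing available explains this result. As far as these compounds go, whether 3-fluorophenyl, unsubstituted phenyl or a chlorophenyl group at this place would give a number beyond the scatter stays open. So does the effect of an amine or a carboxylic acid on that aromatic ring.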